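The source may report more compounds than this note shows. Statements on the series, on what has been measured and on what is new or still open speak of the compounds shown alone.

Working notes on the series, read in an ADME assay on HEK293 cells (Homo sapiens) for cytotoxicity, read by MTT assay, with a stated time of 48 h; on this read-out lower numbers stand for higher toxicity in this test and higher numbers for lower toxicity in this test. Compound 1 `Cc1ccc(N2C(=O)[C@H](CCCNS(=O)(=O)c3ccc(OC(F)(F)F)cc3)[C@H]2c2ccc([N+](=O)[O-])cc2)cc1`, which carries the trifluoromethoxy group, gives > 100000 nM, a limit of the assay and not a number. On these data alone, compound 2 `CCc1ccc(S(=O)(=O)NCCC[C@H]2C(=O)N(c3ccc(C)cc3)[C@@H]2c2ccc(NS(C)(=O)=O)cc2)cc1` gives > 100000 nM, also a limit and not a number, so its true position is unknown. Both measured compounds share this position: the limit of > 100000 nM in this assay, at which 2 of the 2 values shown sit.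

Compound 3 `Cc1ccc(N2C(=O)[C@H](CCCNS(=O)(=O)c3ccc(OC(F)(F)F)cc3)[C@H]2c2ccc(NS(C)(=O)=O)cc2)cc1` follows from compound 2 by one change, trifluoromethoxy in place of ethyl on an aromatic carbon. For the measured compounds named here, no step between measured compounds is available in this assay to size this change. With compound 1 at > 100000 nM, no step beyond the scatter is expected, in either direction. The expected step, a number no higher from compound 2 to compound 3 (the limit leaves the size open), is therefore small. For compound 3 the estimate is 100000 nM, with an expected range of 50000 nM to 200000 nM.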

Compound 3, concentration lethal to 50% of the cells in the HEK293 assay: > 100000 nM
Compound 3: only a limit was reported; the forecaster's own chance of this, stated with the estimate: 85%; the middle value lies on the limit itself.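

In the HEK293 assay compound 3 gives > 100000 nM as a limit and not a number.

The steps to compound 3 from compound 1 and from compound 2 therefore cannot be read: the limit of > 100000 nM in the HEK293 assay, at which 3 of the 3 values shown sit.

The compounds shown leave open where any of the three truly stands in the HEK293 assay, and whether either change moves the value at all.

In a physicochemical assay for lipophilicity, read by HPLC, measured as octanol-water partition (a lower number here means a more polar compound, a higher number a more lipophilic compound), compound 2 gives 3.4 and compound 3 gives 3.4 so the result is no change at the digits printed from compound 2 to compound 3 (within the scatter) with trifluoromethoxy in place of ethyl on an aromatic carbon.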